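Permeability notes on an aryl swap in the oxazole-piperidine series

This account rests on a few compounds, and the source may have more. Where it says the series, first, only, none or still open, it means among the compounds named here.

Measured so far:
- compound 1 `Cc1ccccc1-c1nc(CN2CCC(C(=O)NCCCN3CCC(C(C)C)CC3)CC2)c(C)o1`: 396 10^-6 cm/s
- compound 2 `Cc1ccccc1-c1nc(CN2CCC(C(=O)NCCCN3CCC(C)CC3)CC2)c(C)o1`: 425 10^-6 cm/s
- compound 3 `Cc1oc(-c2c(Cl)cccc2Cl)nc1CN1CCC(C(=O)NCCCN2C[C@H](C)C[C@H](C)C2)CC1`: "not determined" (no result reported)

Among the compounds with values here, in a physicochemical assay for permeability, using PAMPA (on this read-out higher numbers stand for higher permeability and lower numbers for lower permeability), compound 1 gives 396 10^-6 cm/s and compound 2 gives 425 10^-6 cm/s; the one step between them, a 1.1-fold higher number from compound 1 to compound 2 (0.03 log units; within the scatter), changes only the methyl for the isopropyl on a saturated ring carbon and says nothing about the aromatic ring on the shared core. Compound 3 stands nowhere on the numbers shown: in this assay compound 3 gives "not determined" (no result reported), so its place can only be inferred from the other two.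

Compound 4 `Cc1ccc(-c2nc(CN3CCC(C(=O)NCCCN4C[C@H](C)C[C@H](C)C4)CC3)c(C)o2)cc1` differs from compound 3 by 4-methylphenyl in place of 2,6-dichlorophenyl on an aromatic carbon. Within the data shown here, no measured step touches this position, so nothing sets a direction for this assay here. Among the measured compounds shown here, the only guide is that compound 1 and compound 2, which carry a methyl-substituted phenyl on the same position of the shared core and a closely related tail, both gave high numbers in this assay, and compound 4 carries a 4-methylphenyl at that place. Compound 4 is therefore expected to fall in the same high region in this assay, at about 400 10^-6 cm/s, with a range of 200 10^-6 cm/s to 800 10^-6 cm/s.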

Compound 4, apparent permeability: 274 10^-6 cm/s
For compound 4 the middle estimate is 1.5-fold (0.16 log units) above the measured one; low and high end bracket the measured number.
By their numbers in this assay, from the lowest: compounds 4, 1 and 2 (each within the scatter of the next).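

In this assay compound 3 gives "not determined" (no result reported) and compound 4 gives 274 10^-6 cm/s with no number to set against it, so no new step can be read between compound 3 and compound 4. What 4-methylphenyl in place of 2,6-dichlorophenyl does to this read-out stays open on the compounds shown. No supporting evidence bears on this result.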